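Trading 2-carboxycyclopropyl for 2-carboxyethenyl on the chain

The compounds below may be only part of what the source reports. "The series", "measured", "known", "first", "only" and "open" are said of these compounds alone.

Of the compounds shown here, three built on a shared core have been measured in an ADME assay on the whole organism (strain CD-1) for pharmacokinetics, with Mus musculus as the target, at a dose of 3 mg/kg by the intravenous route; a higher number here means more compound in the circulation at the dose given, a lower number less compound in the circulation. Compound 1 `CN(Cc1ccccc1OCCCCCC(=O)O)C(=O)c1ccc(-c2ccco2)cc1` gives 1100 ng.h/mL, compound 2 `CC(CCCCOc1ccccc1CN(C)C(=O)c1ccc(-c2ccco2)cc1)C(=O)O` gives 11400 ng.h/mL, and compound 3 `CN(Cc1ccccc1OCCC[C@@H]1C[C@@H]1C(=O)O)C(=O)c1ccc(-c2ccco2)cc1` gives 30100 ng.h/mL, the highest of the three numbers.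

The unmeasured compound 4 `CN(Cc1ccccc1OCCC/C=C/C(=O)O)C(=O)c1ccc(-c2ccco2)cc1` differs from compound 3 in one place: 2-carboxyethenyl in place of 2-carboxycyclopropyl on a saturated chain carbon, three bonds along the chain from an oxygen on an aromatic ring. There, 2-carboxyethenyl stands in place of 2-carboxycyclopropyl on a saturated chain carbon, three bonds along the chain from an oxygen on an aromatic ring.

Among the measured compounds shown here, three measured steps bear on this change. Putting 2-carboxycyclopropyl in place of 2-carboxyethyl gave a 27-fold higher number from compound 1 to compound 3 (1.44 log units; beyond the scatter), the largest of them. Methyl in place of hydrogen on a saturated chain carbon bound to a carbonyl carbon and a saturated chain carbon gave a 10-fold higher number from compound 1 to compound 2 (1.02 log units; beyond the scatter). The remaining step is smaller, at a 2.6-fold higher number from compound 2 to compound 3 (0.42 log units; beyond the scatter).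

For the measured compounds named here, no measured compound carries 2-carboxyethenyl, so the data offer no direct comparison. Compound 4 has neither the ring nor the methyl that came with the two large gains, yet it does not return to the saturated chain of compound 1. A clear fall from compound 3 is therefore expected, though probably not all the way to compound 1. The expected change is a 5.0-fold lower number from compound 3 to compound 4 (0.70 log units; beyond the scatter). Compound 4 is estimated at 6000 ng.h/mL, within an expected range of 1800 ng.h/mL to 20000 ng.h/mL.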

Compound 4, area under the concentration-time curve: 750 ng.h/mL
For compound 4 the middle estimate is 8.0-fold (0.90 log units) above the measured one, and the stated range ends above it.
By their numbers in this assay, from the lowest: compounds 4 and 1 (each within the scatter of the next); then compound 2; then compound 3.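

In this assay the position proves far from indifferent to what replaces the saturated end of the chain: 2-carboxyethenyl keeps none of the gain seen with 2-carboxycyclopropyl, with a 40-fold lower number from compound 3 to compound 4 (1.60 log units; beyond the scatter) and none of the gain seen with 2-carboxypropyl, with a 15-fold lower number from compound 2 to compound 4 (1.18 log units; beyond the scatter) as the matching step. Against the plain saturated chain the change is not resolved, with a 1.5-fold lower number from compound 1 to compound 4 (0.17 log units; within the scatter) so that 2-carboxyethenyl and 2-carboxyethyl cannot be told apart in these numbers, and departing from the saturated chain is therefore not enough by itself to bring a gain here. Nothing available accounts for why the ring and the methyl go with higher numbers while 2-carboxyethenyl does not.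

The compounds shown leave open whether a larger ring, such as 2-carboxycyclobutyl, would hold the high number of compound 3. They also leave open whether a methyl on the 2-carboxyethenyl group would bring a gain like the one that came with the methyl of compound 2 on the saturated chain.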